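Moving the isopropyl group on the phenyl ring

The source may hold more compounds than are shown below. What is called first, only, known or untested is meant among the compounds shown, and "the series" means these compounds.

Compound 1 `CN1CCN(c2ccc(Nc3ncc(Cl)c(NCc4ccc(C(F)(F)F)cc4)n3)nc2)CC1` gives 7960 nM
Compound 2 `CCc1ccc(Nc2nc(Nc3ccc(N4CCN(C)CC4)cn3)ncc2Cl)cc1` gives 11100 nM
Compound 3 `CC(C)c1cccc(Nc2nc(Nc3ccc(N4CCN(C)CC4)cn3)ncc2Cl)c1` gives 12300 nM

These values come from a functional assay on Jurkat cells (Homo sapiens) for inhibition, read by CCK-8 assay, with a stated time of 48 h (a higher number here means a weaker inhibitor of growth, a lower number a stronger inhibitor of growth), and they lie close together. Compound 3 at 12300 nM stands level with the other two, and its steps are a 1.1-fold higher number from compound 2 to compound 3 (0.04 log units; within the scatter) and a 1.5-fold higher number from compound 1 to compound 3 (0.19 log units; within the scatter) on the evidence so far.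

Compound 4 `CC(C)c1ccccc1Nc1nc(Nc2ccc(N3CCN(C)CC3)cn2)ncc1Cl` has the same atoms as compound 3, joined differently (2-isopropylphenyl in place of 3-isopropylphenyl on a nitrogen on an aromatic ring). It carries 2-isopropylphenyl in place of 3-isopropylphenyl on a nitrogen on an aromatic ring.

Among the compounds with values here, no measured compound carries 2-isopropylphenyl, so the evidence is indirect. The nearest guide is a change of group at that same nitrogen, seen in a 1.1-fold higher number from compound 2 to compound 3 (0.04 log units; within the scatter) and also in a 1.4-fold higher number from compound 1 to compound 2 (0.14 log units; within the scatter) as a second case. All three groups tried there give numbers that cannot be separated, so no step beyond the scatter is expected in this assay for this change. The expected step is a 1.1-fold lower number from compound 3 to compound 4 (0.05 log units; within the scatter) and it has no clear direction. For compound 4 the estimate is 11000 nM with an expected range from 5500 nM to 22000 nM as the likely span.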

Compound 4, concentration for 50% growth inhibition: 5140 nM
Compound 4: the middle estimate sits 2.1-fold (0.33 log units) above what was measured, and the stated range ends above it.
By their numbers in this assay, from the lowest: compounds 4, 1, 2 and 3 (each within the scatter of the next, the first and the last beyond it).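

In this assay, the earlier changes at this nitrogen gave only steps within the scatter, whereas moving the isopropyl group gives a 2.4-fold lower number from compound 3 to compound 4 (0.38 log units; beyond the scatter), a modest step beyond it. Since compounds 3 and 4 have the same atoms joined differently, this pair shows that the place of the isopropyl group on the phenyl ring can change the result even when the composition stays the same. The 2-isopropylphenyl group also separates from 4-ethylphenyl, with a 2.2-fold lower number from compound 2 to compound 4 (0.33 log units; beyond the scatter), but not from 4-(trifluoromethyl)benzyl, with a 1.5-fold lower number from compound 1 to compound 4 (0.19 log units; within the scatter), so compound 4 cannot be ranked against compound 1; nothing measured here accounts for the effect of moving the isopropyl group.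

As far as these compounds go, whether the step belongs to the isopropyl group itself remains open, and a methyl or methoxy group on the phenyl ring in its place would help to test that. From the compounds shown here alone, the step also rests on a single pair of compounds, so it remains unknown whether the same move would matter with a different group on the shared core, such as a morpholine in place of the methylpiperazine.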